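The compounds below may be only part of what the source reports. "The series", "measured", "known", "first", "only" and "open" are said of these compounds alone.

Measured compounds:
compound 1, `Cc1ccc(-c2csc(NC(=O)COc3ccc(Br)cc3)n2)cc1`, in a functional assay on MCF7 cells (Homo sapiens) for cytotoxicity, read by trypan blue exclusion, with a stated time of 48 h (on this read-out higher numbers stand for weaker inhibition and lower numbers for stronger inhibition), compound 1 gives 39000 nM
compound 2, `O=C(COc1ccc(Br)cc1)Nc1nc(-c2ccc(Br)cc2)cs1`, in this assay compound 2 gives 44500 nM

Going by the values given here, on these two numbers compound 2 sits alongside compound 1; the only step measured, a 1.1-fold higher number from compound 1 to compound 2 (0.06 log units; within the scatter), separates them within the scatter.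

Compound 3, `Cc1ccc(OCC(=O)Nc2nc(-c3ccc(Br)cc3)cs2)cc1`, is not yet measured in this assay. It differs from compound 2 by methyl in place of bromo on an aromatic carbon. Among the compounds with values here, the one measured step that bears on this is the same swap at another aromatic carbon, taken the other way round, a 1.1-fold higher number from compound 1 to compound 2 (0.06 log units; within the scatter), and it stayed within the scatter. Within the data shown here, no measured step speaks to this exact place. On that basis a step of no size beyond the scatter in this assay is expected, and compound 3 is estimated at 40000 nM, within 20000 nM to 80000 nM, which means an expected step of a 1.1-fold lower number from compound 2 to compound 3 (0.05 log units; within the scatter).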

Compound 3, half-maximal inhibitory concentration: 52400 nM
The estimate for compound 3 lay 1.3-fold (0.12 log units) below the measured number, within the range that was stated.
By their numbers in this assay, from the lowest: compounds 1, 2 and 3 (each within the scatter of the next).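

In this assay, the swap of bromo for methyl now has a reading on the other aromatic ring: going from 4-bromophenoxy to 4-methylphenoxy gives a 1.2-fold higher number from compound 2 to compound 3 (0.07 log units; within the scatter). Together with a 1.1-fold higher number from compound 1 to compound 2 (0.06 log units; within the scatter), taken on the 4-bromophenyl to 4-methylphenyl side and in the opposite direction, this means that the exchange of these two groups has stayed within the scatter at both ends of the shared core, not just at one. The evidence at hand gives no explanation for this result.

These compounds leave open how this position would respond to a group other than bromo or methyl, such as an amine, a carboxylic acid or a longer alkyl chain. They also leave open whether a plain hydrogen there would read any differently.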